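Fluoro to methoxy on a cytotoxicity series

The compounds below may be only part of what the source reports. "The series", "measured", "known", "first", "only" and "open" are said of these compounds alone.

Compound 1 `O=C(O)c1cn(C2CC2)c2cc(N3CCN(Cn4nc(-c5cccc(O)c5)n(Cc5ccc(F)cc5)c4=S)CC3)c(F)cc2c1=O` and compound 2 `COc1ccc(Cn2c(-c3cccc(O)c3)nn(CN3CCN(c4cc5c(cc4F)c(=O)c(C(=O)O)cn5C4CC4)CC3)c2=S)cc1` share a core and differ in methoxy in place of fluoro on an aromatic carbon. In an ADME assay on HEK293 cells (Homo sapiens) for cytotoxicity, read by MTT assay, with a stated time of 72 h (a lower number here means that less compound is needed, a higher number that more compound is needed for the effect), compound 1 gives 69500 nM, and compound 2 gives 62900 nM, so that a 1.1-fold lower number from compound 1 to compound 2 (0.04 log units; within the scatter). Compound 3 `O=C(O)c1cn(C2CC2)c2cc(N3CCN(Cn4nc(-c5ccc(O)cc5)n(-c5ccc(F)cc5)c4=S)CC3)c(F)cc2c1=O` belongs to the same series, but the difference between its core and that of compound 1 is not broken down here; in this assay compound 3 gives 106000 nM. Compound 4 `COc1ccc(-n2c(-c3ccc(O)cc3)nn(CN3CCN(c4cc5c(cc4F)c(=O)c(C(=O)O)cn5C4CC4)CC3)c2=S)cc1` is not yet measured and differs from compound 3 in methoxy in place of fluoro on an aromatic carbon, the same change that separates compound 1 from compound 2. Since that earlier step stayed within the scatter, compound 4 is expected to sit close to compound 3, with an estimated step of a 1.1-fold lower number from compound 3 to compound 4 (0.05 log units; within the scatter). The estimate for compound 4 is 95000 nM, between 50000 nM and 190000 nM.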

Compound 4, half-maximal effective concentration: 105000 nM
Estimate against measurement, compound 4: 1.1-fold (0.04 log units) below; the range from low to high includes it.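

In this assay the step from fluoro to methoxy reads a 1.0-fold lower number from compound 3 to compound 4 (0.00 log units; within the scatter), so the 4-fluorophenyl to 4-methoxyphenyl change makes no difference beyond the scatter on this core. The step on this core also agrees with the one seen earlier on the other core: the same change on two cores in this assay, a 1.1-fold lower number (0.04 log units; within the scatter) from compound 1 to compound 2 and a 1.0-fold lower number (0.00 log units; within the scatter) from compound 3 to compound 4, 1.1-fold (0.04 log units) apart, within the scatter of two such steps. This shows that the change carried across these two cores without a measurable effect in this one cytotoxicity read-out, but it does not show that the same would hold on any other core or in any other assay.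

The compounds shown leave open whether an amine or a longer chain such as butoxy in the same place would also stay within the scatter. Only fluoro and methoxy appear there.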